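The source may report more compounds than this note shows. Statements on the series, on what has been measured and on what is new or still open speak of the compounds shown alone.

Working notes on the series in a functional assay (aorta) with Rattus norvegicus as the target; on this read-out higher numbers stand for weaker inhibition and lower numbers for stronger inhibition. Compound 1 `CCO/C(O)=C1\C(COCCNc2n[nH]c(N)n2)=NC(C)=C(C(=O)OC)C1c1ccccc1Cl` gives 20 nM in this assay. Compound 2 `CCO/C(O)=C1\C(COCC/N=C(/N)S)=NC(C)=C(C(=O)OC)C1c1cccc(Cl)c1Cl` gives 1 nM in this assay, the lowest number of the two shown, with compound 1 standing beyond the scatter above it. Compound 3 `CCO/C(O)=C1\C(COCCNc2n[s+]([O-])nc2N)=NC(C)=C(C(=O)OC)C1c1cccc(Cl)c1Cl` differs from compound 2 by a group of 8 heavy atoms (2 carbon, 4 nitrogen, 1 oxygen, 1 sulfur; one five-membered aromatic ring with 3 hetero atoms) in place of a group of 4 heavy atoms (1 carbon, 2 nitrogen, 1 sulfur; no ring), on a saturated chain carbon, two bonds along the chain from an oxygen on a saturated carbon. Among the measured compounds shown here, no measured pair shows this change, so the step from compound 2 to compound 3 is expected to be modest and towards weaker inhibition, as a 5.0-fold higher number from compound 2 to compound 3 (0.70 log units; beyond the scatter). For compound 3 a value of 5 nM is estimated, within a range of 1 nM to 30 nM.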

Compound 3, half-maximal inhibitory concentration: 15.9 nM
Compound 3: middle estimate off by 3.2-fold (0.50 log units), on the low side; low and high end bracket the measured number.
By their numbers in this assay, from the lowest: compound 2; then compounds 3 and 1 (each within the scatter of the next).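

On this saturated chain carbon, two bonds along the chain from an oxygen on a saturated carbon, the change to the five-membered aromatic ring with 3 hetero atoms gives, in this assay, a 16-fold higher number from compound 2 to compound 3 (1.20 log units; beyond the scatter). The position is therefore sensitive to the group it carries, although compound 3 still reads 15.9 nM. Nothing available bears on the cause of this step. Open, going by these compounds, is whether the shift belongs to this particular ring or to any ring here. A primary amine or a carboxylic acid at this place, or a longer chain carrying the same ring, would help to separate these.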